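A few compounds are considered here, and "the series" means these few. Any claim that something is new, unique, unknown or untested is made for them only; others in the source may bear on it.

In a functional assay on the whole organism with Mus musculus as the target (on this read-out lower numbers stand for an effect already at smaller amounts and higher numbers for an effect only at larger amounts of compound), compound 1 `CC[C@@H](C(=O)NC)N1CCCC1=O` gives 1800 umol/kg and compound 2 `CC[C@@H](C(=O)NO)N1CCCC1=O` gives 1000 umol/kg. Going by the values given here, the only measured step is a 1.8-fold lower number from compound 1 to compound 2 (0.26 log units; within the scatter), so neither compound stands apart on these numbers. Compound 3 `CC[C@@H](C(=O)N(C)O)N1CCCC1=O` has methyl in place of hydrogen on an amide-type nitrogen of compound 2 (methyl in place of hydrogen on an amide-type nitrogen). The measured step changed the group on that same nitrogen and stayed within the scatter, so no change beyond the scatter is expected in this assay. The expected step is no change at the digits printed from compound 2 to compound 3 (within the scatter). For compound 3 the estimate is 1000 umol/kg, with an expected range from 450 umol/kg to 2200 umol/kg.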

Compound 3, dose for half-maximal effect: 1000 umol/kg
Beside the measured number, compound 3's estimate shows no gap at the digits printed; low and high end bracket the measured number.
By their numbers in this assay, from the lowest: compounds 2, 3 and 1 (each within the scatter of the next).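

In this assay, methyl in place of hydrogen on the amide-type nitrogen gives no change at the digits printed from compound 2 to compound 3 (within the scatter), and hydroxy in place of hydrogen on that nitrogen gives a 1.8-fold lower number from compound 1 to compound 3 (0.26 log units; within the scatter). This nitrogen thus carries methyl, hydroxy or both, and none of the three compounds stands apart on these numbers. Nothing available explains how close these numbers lie.

From the compounds shown here alone, it remains open whether a longer chain or a benzyl group on that nitrogen would give a step beyond the scatter. The same holds for a carboxylic acid in place of the hydroxy(methyl)amino amide.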